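Allyloxy in Place of Methoxy: Expected Cytotoxicity in HEL Cells

The source may report more compounds than this note shows. Statements on the series, on what has been measured and on what is new or still open speak of the compounds shown alone.

Compound 1 `CCC1(Cc2ccccc2)OS(=O)(=O)C=C1OCC(=O)OC`: in an ADME assay on HEL cells (Homo sapiens) for cytotoxicity, with a stated time of 3 days (on this read-out higher numbers stand for lower toxicity in this test and lower numbers for higher toxicity in this test), compound 1 gives > 200000 nM, which is a limit of the test rather than a number.
Compound 2 `CCC1(Cc2ccccc2)OS(=O)(=O)C=C1OC`: compound 2 gives > 200000 nM, again a limit.
Compound 3 `CC1(C(c2ccccc2)c2ccccc2)OS(=O)(=O)C=C1OCc1ccccc1`: compound 3 gives 200000 nM.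

Compound 2 thus stands at the limit of this assay, where most of the shown values sit, as the limit of > 200000 nM in this assay, at which 2 of the 3 values shown sit, records. Compound 4 `C=CCOC1=CS(=O)(=O)OC1(CC)Cc1ccccc1` has not been measured. It differs from compound 2 by vinyl in place of hydrogen on a saturated chain carbon bound to an oxygen on an unsaturated carbon. Going by the values given here, the only measured step at this position, a step that the two limits leave unreadable from compound 1 to compound 2, gives no readable size. No change beyond the scatter is therefore expected, so the step that the limit leaves unreadable from compound 2 to compound 4 is estimated to be flat. Compound 4 is expected at 250000 nM, within 150000 nM to 400000 nM.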

Compound 4, half-maximal cytotoxic concentration: > 200000 nM
Compound 4 ended at the assay's limit; the forecaster's own chance of this, stated with the estimate: 80%; the middle value lies beyond the limit too.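

Compound 1, compound 2 and compound 4 all stand at a limit of this assay, so no step among them can be read: the limit of > 200000 nM in this assay, at which 3 of the 4 values shown sit.

Going by these compounds, whether methoxy and allyloxy differ at all in this assay remains open.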